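The source may report more compounds than this note shows. Statements on the series, on what has been measured and on what is new or still open speak of the compounds shown alone.

Working notes on the series. Of the compounds shown here, three share a core and have been measured in an assay on RBL-1 cells for inhibition of Polyunsaturated fatty acid 5-lipoxygenase (Rattus norvegicus); on this read-out lower numbers stand for stronger inhibition and higher numbers for weaker inhibition. Compound 1 `Cc1ccccc1N1CCNC(=O)N1` gives 386000 nM in this assay. Compound 2 `COc1cccc(N2CCNC(=O)N2)c1` gives 47000 nM. Compound 3 `CCC1CN(c2ccccc2)NC(=O)N1` gives 6900 nM, the lowest of the three numbers; its gap to compound 2 and its larger gap to compound 1 both lie beyond the usual scatter, so compound 3 stands as the most potent of the measured set. No pair among these three differs in only one place, so no single-point step is available from the measured compounds.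

Compound 4 `CCCCC1CN(c2ccccc2)NC(=O)N1` is not yet measured. It differs from compound 3 by ethyl in place of hydrogen on a saturated chain carbon, two bonds along the chain from a saturated ring carbon. Within the data shown here, no measured step of this kind exists, so the size of the change in this assay can only be expected, not read off. The expectation is a small shift, if any, with a slight lean toward a lower number, and a real chance that the step stays within the scatter. For compound 4 the estimate in this assay is 5000 nM, within a range from 1500 nM to 17000 nM. This estimate means an expected step of a 1.4-fold lower number from compound 3 to compound 4 (0.14 log units; within the scatter).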

Compound 4, half-maximal inhibitory concentration: 1500 nM
Compound 4: middle estimate off by 3.3-fold (0.52 log units), on the high side; the measured number falls inside the stated range.
By their numbers in this assay, from the lowest: compound 4; then compound 3; then compound 2; then compound 1.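

In this assay, among these compounds, this position on the saturated chain carbon, two bonds along the chain from a saturated ring carbon, proves responsive: ethyl in place of hydrogen gives a 4.6-fold lower number from compound 3 to compound 4 (0.66 log units; beyond the scatter) and this is the first single-place change that can be read. Read one bond further out, the same difference is ethyl to butyl, so on this one pair the longer chain goes with the lower number, a modest step that stands beyond the scatter. Nothing at hand offers an explanation for the size of this step.

On these data alone, whether a longer chain such as hexyl lowers the number further or reverses the step remains open. Also open, as far as these compounds go, is how an amine or a carboxylic acid carried on this chain would compare with butyl.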